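The compounds below may be only part of what the source reports. "The series", "measured", "known", "first", "only" and "open" are said of these compounds alone.

Working notes on the series in a functional assay on MCF7 cells (Homo sapiens) for cytotoxicity, read by MTT assay, with a stated time of 72 h; on this read-out higher numbers stand for lower toxicity in this test and lower numbers for higher toxicity in this test.

Compound 2 `CSc1ccc(CNc2nc([SeH])nc3ccccc23)cc1` is the parent of the step at hand. In this assay compound 2 gives > 100000 nM, which is a limit of the assay and not a number. Compound 1 `COc1ccc(CNc2nc([SeH])nc3ccccc23)cc1` carries methoxy where compound 2 carries methylsulfanyl; in this assay compound 1 gives > 100000 nM, a limit. Compound 3 `[SeH]c1nc(NCc2ccccc2)c2ccccc2n1` carries hydrogen at that place; in this assay compound 3 gives > 100000 nM, a limit. Thus all three measured values sit at the limit of > 100000 nM in this assay, at which 3 of the 3 values shown sit.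

The steps among them, a step that the two limits leave unreadable from compound 1 to compound 2, a step that the two limits leave unreadable from compound 1 to compound 3 and a step that the two limits leave unreadable from compound 2 to compound 3, are unreadable in size, and none of them touches the selenium.

Compound 4 `CSc1ccc(CNc2nc([Se]C)nc3ccccc23)cc1` differs from compound 2 by methyl in place of hydrogen on a selenium. For the measured compounds named here, no measured step bears on that change, so there is no ground to expect a step in this assay in either direction beyond the scatter.

Compound 4 is therefore expected near the limit, estimated at 100000 nM (range 30000 nM to 300000 nM), the expected step from compound 2 to compound 4 being a number no higher from compound 2 to compound 4 (the limit leaves the size open).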

Compound 4, concentration lethal to 50% of the cells: > 100000 nM
Compound 4: no number, only a limit; the forecaster's own chance of this, stated with the estimate: 70%; the middle value sits exactly at the limit.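

Compound 2 and compound 4 both stand at a limit of the assay and not at a number, so no step between them can be read: the limit of > 100000 nM in this assay, at which 4 of the 4 values shown sit.

The compounds shown leave open whether methyl in place of hydrogen on a selenium, or any other change shown, moves the value in this assay at all.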